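This account rests on a few compounds, and the source may have more. Where it says the series, first, only, none or still open, it means among the compounds named here.

Compound 1, `COC(=O)c1sccc1NC(=O)CSc1nncnc1-c1ccccc1Cl`, gives 105000 nM in an ADME assay on MT4 cells (Homo sapiens) for cytotoxicity, read by MTT assay; a higher number here means that more compound is tolerated, a lower number that less compound is tolerated.
Compound 2, `Cc1ccc(NC(=O)CSc2nncnc2-c2cccc3ccccc23)c(Br)c1`, gives 166000 nM in this assay.
Compound 3, `O=C(CSc1nncnc1-c1cccc2ccccc12)N1CCc2ccccc2C1`, gives 13000 nM in this assay.

Compound 2 holds the highest number of the three in this assay. Its nearest neighbour is compound 1, whose number is within the scatter of that of compound 2, so the two cannot be ordered. Compound 3 lies furthest away: a 13-fold lower number from compound 2 to compound 3 (1.11 log units; beyond the scatter), and that step came from exchanging the amide substituent on the carbonyl carbon.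

The unmeasured compound 4, `Cc1ccc(NC(=O)CSc2nncnc2-c2cccc3ccccc23)c([N+](=O)[O-])c1`, differs from compound 2 in another way: nitro in place of bromo on an aromatic carbon. Within the data shown here, the only step measured changes a different part of the molecule, so no measured step bears on the swap of bromo for nitro on the aromatic ring. What remains is that compound 2 and compound 1, with different aryl and amide parts, sit within the scatter of each other, which gives no sign that small changes on an aromatic carbon move the number much here. Compound 4 is therefore expected to stay close to compound 2, with a 1.1-fold lower number from compound 2 to compound 4 (0.04 log units; within the scatter) expected to fall within the scatter. The estimate for compound 4 in this assay is 150000 nM, with a range from 60000 nM to 400000 nM.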

Compound 4, half-maximal cytotoxic concentration: 147000 nM
Compound 4: middle estimate off by 1.0-fold (0.01 log units), on the high side; low and high end bracket the measured number.
By their numbers in this assay, from the lowest: compound 3; then compounds 1, 4 and 2 (each within the scatter of the next).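

Nitro in place of bromo, on an aromatic carbon ortho to a large group and meta to a methyl group, gives a 1.1-fold lower number from compound 2 to compound 4 (0.05 log units; within the scatter) in this assay, and this is the only measured step at this position. Here 1 heavy atom gives way to 3 heavy atoms and 2 hydrogen-bond acceptors enter, yet compound 2 and compound 4 cannot be ordered, so in this pair the exchange leaves the number unresolved from its starting point, unlike the amide exchange that gives a 13-fold lower number from compound 2 to compound 3 (1.11 log units; beyond the scatter). Nothing measured alongside these numbers accounts for this outcome.

The compounds shown leave open whether other groups on this aromatic carbon, such as an amine or a carboxylic acid, would also stay within the scatter of compound 2, since a single exchange cannot show how widely the result holds. They also leave open whether the same exchange would give a similar result with a longer chain, such as ethyl, in place of the methyl group, or with the tetrahydroisoquinoline amide of compound 3 in place of the anilide.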